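Losing the hydroxy group from compound 3

The source may report more compounds than this note shows. Statements on the series, on what has been measured and on what is new or still open speak of the compounds shown alone.

Measured in a functional assay on MCF7 cells (Homo sapiens) for cytotoxicity, read by MTT assay, with a stated time of 72 h; a lower number here means a stronger inhibitor, a higher number a weaker inhibitor:
- Compound 1 `O=C1C(=Cc2ccc(O)cc2)C(=O)N(c2ccc(Cl)cc2)N1c1ccc(Cl)cc1`: 23200 nM
- Compound 2 `CN(C)c1ccc(C=C2C(=O)N(c3ccc(Cl)cc3)N(c3ccc(Cl)cc3)C2=O)cc1`: > 128000 nM (a limit, not a number)
- Compound 3 `COc1cccc(C=C2C(=O)N(c3ccc(Cl)cc3)N(c3ccc(Cl)cc3)C2=O)c1O`: 26700 nM

Compound 3 gives 26700 nM. Within the data shown here, its only close neighbour differs by a 1.2-fold higher number from compound 1 to compound 3 (0.06 log units; within the scatter), which is within the scatter, so these two hydroxy-bearing compounds cannot be told apart. Compound 2 gives only a limit, > 128000 nM.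

Compound 4 `COc1ccc(C=C2C(=O)N(c3ccc(Cl)cc3)N(c3ccc(Cl)cc3)C2=O)cc1` has not been measured. It carries 4-methoxyphenyl in place of 2-hydroxy-3-methoxyphenyl on a double-bonded chain carbon bound to a double-bonded ring carbon.

Among the measured compounds shown here, two measured steps beyond the scatter bear on this change, both involving compound 2, the one measured compound without a hydroxy group. Dimethylamino in place of hydroxy gave an at least 5.5-fold higher number from compound 1 to compound 2 (0.74 log units; beyond the scatter), and the comparison with compound 3 gave an at least 4.7-fold lower number from compound 2 to compound 3 (0.68 log units; beyond the scatter). Compound 4 also lacks a hydroxy group, so a weaker result is expected, but its methoxy group differs from the dimethylamino group of compound 2, and that compound offers only a limit as a guide. The expected change is a 2.2-fold higher number from compound 3 to compound 4 (0.35 log units; beyond the scatter) in this assay. For compound 4 the estimate is 60000 nM, with an expected range from 24000 nM to 128000 nM.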

Compound 4, half-maximal inhibitory concentration: > 128000 nM
Compound 4: no number, only a limit (the forecaster's own chance of this, stated with the estimate: 30%); middle value at least 2.1-fold (0.32 log units) from the limit.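

In this assay, the only earlier loss came with dimethylamino replacing the hydroxy group outright, whereas here methyl in place of hydrogen on an oxygen on an aromatic ring, which keeps the oxygen, gives an at least 5.5-fold higher number from compound 1 to compound 4 (0.74 log units; beyond the scatter). The change from 2-hydroxy-3-methoxyphenyl to 4-methoxyphenyl gives an at least 4.7-fold higher number from compound 3 to compound 4 (0.68 log units; beyond the scatter), so among these four compounds the two with a free hydroxy group give numbers and the two without one do not, and no compound goes against this. Compound 4 gives a limit and not a number, so these two steps are minimum sizes, and the step from compound 2 to compound 4 cannot be read because both compounds stop at the same limit: the limit of > 128000 nM in this assay, at which 2 of the 4 values shown sit.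

Going by these compounds, it stays open whether the loss belongs to the hydroxy group alone, since the step from compound 3 to compound 4 also changes where the methoxy group sits on the phenyl ring. A carboxylic acid in place of the hydroxy group, or a longer chain on its oxygen, would test whether anything other than a free hydroxy group can keep a measurable number.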